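A few compounds are considered here, and "the series" means these few. Any claim that something is new, unique, unknown or untested is made for them only; others in the source may bear on it.

The series shares one core, first seen in compound 1 `CCNc1nc(-c2ccccc2)nc2c1nnn2Cc1ccccc1`, which in an assay on Cerebral cortex for displacement of a labelled ligand from adenosine receptor A1 (Bos taurus) (on this read-out lower numbers stand for stronger inhibition and higher numbers for weaker inhibition), gives 91 nM. Compound 2 `CCNc1nc(-c2ccccc2)nc2c1nnn2Cc1ccccc1Cl` carries a chloro in place of hydrogen on an aromatic carbon, and in this assay compound 2 gives 463 nM; the step of a 5.1-fold higher number from compound 1 to compound 2 (0.71 log units; beyond the scatter) lies beyond the scatter. Compound 3 `CCNc1nc(-c2ccccc2)nc2c1nnn2Cc1ccccc1C(F)(F)F` bears a trifluoromethyl instead of that chloro, but in this assay compound 3 stands at "not determined" (no result reported), so it contributes no number. Among the two numbers available, compound 2 therefore has the higher one, and its nearest neighbour is compound 1 with the lower value.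

Compound 4 `Clc1ccccc1Cn1nnc2c(NC3CC3)nc(-c3ccccc3)nc21` keeps the chloro of compound 2 and differs from it by cyclopropyl in place of ethyl on a nitrogen on an aromatic ring. Among the compounds with values here, no measured pair in this set alters the group on that nitrogen; the only measured step, from compound 1 to compound 2, concerns the aromatic carbon and so says nothing about this exchange. Within the data shown here, with no measured counterpart, the writer expects a step no larger than the usual scatter, a 1.3-fold lower number from compound 2 to compound 4 (0.12 log units; within the scatter), with the direction open. He estimates compound 4 in this assay at 350 nM, within a range from 120 nM to 1000 nM.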

Compound 4, inhibition constant: 11 nM
Beside the measured number, compound 4's estimate is 32-fold (1.50 log units) above it; the measured number lies below the stated range.
By their numbers in this assay, from the lowest: compound 4; then compound 1; then compound 2.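

Cyclopropyl in place of ethyl on the nitrogen gives a 42-fold lower number from compound 2 to compound 4 (1.62 log units; beyond the scatter) in this assay and shows that the group on this nitrogen can move the number much further than the earlier compounds revealed. Within the data shown here, the only earlier step, a chloro in place of hydrogen on an aromatic carbon with a 5.1-fold higher number from compound 1 to compound 2 (0.71 log units; beyond the scatter) as its result, ran the other way and was smaller, so the series now holds two changes at different places with opposite outcomes. Nothing given here accounts for the size of the new step, and the exchange itself, ethylamino to cyclopropylamino, changes no count of hydrogen-bond donors or acceptors, so the reason stays unknown.

The compounds shown include no cyclopropyl partner of compound 1, so it remains open whether the same exchange would act with the same size when the chloro is absent. Going by these compounds, it also remains open whether the three-membered ring itself matters or whether other groups on that nitrogen, such as isopropyl, cyclobutyl or a longer chain like propyl, would move the number in the same direction.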